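This account rests on a few compounds, and the source may have more. Where it says the series, first, only, none or still open, it means among the compounds named here.

Compound 1 `CCCc1cc(C)c(C(=O)N=C(N)N)cc1S(C)(=O)=O` gives 5.7 nM in a functional assay for inhibition of sodium/hydrogen exchanger (Oryctolagus cuniculus); a lower number here means a stronger inhibitor, a higher number a weaker inhibitor.
Compound 2 `Cc1cc(-c2cc(Cl)cc(Cl)c2)c(S(C)(=O)=O)cc1C(=O)N=C(N)N` gives 130 nM in this assay.
Compound 3 `Cc1cc(OC(C)C)c(S(C)(=O)=O)cc1C(=O)N=C(N)N` gives 19 nM in this assay.

Compound 3 stands second among the three numbers: its nearest neighbour is compound 1, reached by a 3.3-fold higher number from compound 1 to compound 3 (0.52 log units; beyond the scatter), and its furthest is compound 2, reached by a 6.8-fold lower number from compound 2 to compound 3 (0.84 log units; beyond the scatter). The unmeasured compound 4 `Cc1cc(N2CCC(N)CC2)c(S(C)(=O)=O)cc1C(=O)N=C(N)N` differs from compound 3 by 4-aminopiperidin-1-yl in place of isopropoxy on an aromatic carbon.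

Both measured steps touch the same aromatic carbon. The step of a 23-fold higher number from compound 1 to compound 2 (1.36 log units; beyond the scatter) shows that a large ring group at this position is tolerated poorly, while a 3.3-fold higher number from compound 1 to compound 3 (0.52 log units; beyond the scatter) shows that isopropoxy costs only a modest amount against propyl. Among the compounds with values here, the group entering in compound 4 is again larger than isopropoxy and carries a ring, but it is not aromatic and no measured compound holds anything like it, so the outcome is uncertain. Compound 4 is therefore expected to be a weaker inhibitor than compound 3, by a step of a 2.4-fold higher number from compound 3 to compound 4 (0.37 log units; beyond the scatter) in this assay. The estimate for compound 4 is 45 nM, with a range from 10 nM to 200 nM.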

Compound 4, half-maximal inhibitory concentration: 9.8 nM
For compound 4 the middle estimate is 4.6-fold (0.66 log units) above the measured one; measured number outside the range, below it.
By their numbers in this assay, from the lowest: compounds 1, 4 and 3 (each within the scatter of the next, the first and the last beyond it); then compound 2.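

In this assay, this aromatic carbon ortho to the methylsulfonyl group accepts 4-aminopiperidin-1-yl: a 1.9-fold lower number from compound 3 to compound 4 (0.29 log units; within the scatter) and a 1.7-fold higher number from compound 1 to compound 4 (0.24 log units; within the scatter) both lie within the scatter, so the new group cannot be ranked against either isopropoxy or propyl. A ring at this carbon therefore does not in itself bring the loss seen with 3,5-dichlorophenyl, as a 13-fold lower number from compound 2 to compound 4 (1.12 log units; beyond the scatter) shows. No measurement is available that accounts for this difference between the two ring groups.

The compounds shown leave open whether the amine matters or the non-aromatic ring alone is enough, which a plain piperidin-1-yl or a 4-hydroxypiperidin-1-yl at this carbon would separate. As far as these compounds go, it also remains open whether the poor result with 3,5-dichlorophenyl lies with the phenyl ring or its two chlorines, a question an unsubstituted phenyl would address.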